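A few compounds are considered here, and "the series" means these few. Any claim that something is new, unique, unknown or untested is made for them only; others in the source may bear on it.

Three compounds have been measured in an assay on HeLa cells for inhibition of sphingosine-1-phosphate transporter SPNS2 (Mus musculus), read by LC-MS, tested at 2 uM; on this read-out lower numbers stand for less inhibition and higher numbers for more inhibition at the one concentration tested (going by the name of the read-out):

Compound 1 `CCCCCCCCCCc1ccc(-c2noc([C@@H]3CCNC3)n2)cc1`: 62%
Compound 2 `CCCCCCCCCCc1ccc(-c2noc([C@@H]3CCCN3)n2)cc1`: 21%
Compound 3 `CCCCCCCCCCc1ccc(-c2noc([C@@H]3CCC[C@@H](N)C3)n2)cc1`: 13%

Compound 1 stands highest of the three: the step of a number 41 percentage points lower from compound 1 to compound 2 (beyond the scatter) and the step of a number 49 percentage points lower from compound 1 to compound 3 (beyond the scatter) both lie beyond the scatter, while the step of a number 8 percentage points lower from compound 2 to compound 3 (within the scatter) does not.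

Compound 4 `CCCCCCCCCCc1ccc(-c2noc(CC[C@@H](N)C(=O)O)n2)cc1` has not yet been measured. Against compound 1 the change is 3-amino-3-carboxypropyl in place of pyrrolidin-3-yl on an aromatic carbon. The two measured steps that swap out the pyrrolidin-3-yl group were large falls, and neither of them brings in a 3-amino-3-carboxypropyl group, so the comparison is indirect. A further fall in this assay is nevertheless expected for compound 4, namely a number 42 percentage points lower from compound 1 to compound 4 (beyond the scatter). Compound 4 is estimated at 20%, with a range from 3% to 45%.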

Compound 4, a percentage reported as inhibition, at one concentration (the size of the read-out at that concentration, not a potency): 5%
Beside the measured number, compound 4's estimate is 15 percentage points above it, and the stated range covers the measured number.
By their numbers in this assay, from the lowest: compounds 4, 3 and 2 (each within the scatter of the next, the first and the last beyond it); then compound 1.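

At this position of the core, the open-chain 3-amino-3-carboxypropyl group, which has no ring and carries a carboxylic acid, does not keep the level of the pyrrolidin-3-yl group: a number 57 percentage points lower from compound 1 to compound 4 (beyond the scatter) in this assay. Among the replacements, it shows no clear difference from 3-aminocyclohexyl, a number 8 percentage points lower from compound 3 to compound 4 (within the scatter), but does lie under pyrrolidin-2-yl, a number 16 percentage points lower from compound 2 to compound 4 (beyond the scatter). No measurement here explains these falls.

Opening the ring and adding the carboxylic acid happen together, so their shares of the loss remain unresolved. A 3-aminopropyl chain, with the amine but no carboxylic acid, would test the two apart.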